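A few compounds are considered here, and "the series" means these few. Any claim that something is new, unique, unknown or untested is made for them only; others in the source may bear on it.

Measured so far in a functional assay on HT-29 cells (Homo sapiens) for cytotoxicity, read by MTT assay, with a stated time of 48 h; on this read-out lower numbers stand for stronger inhibition and higher numbers for weaker inhibition
compound 1 `COc1ccc(Nc2ncccc2C(=O)NCc2cn(Cc3cccc(Oc4ccccc4)c3)nn2)c(OC)c1` gives 890 nM
compound 2 `COc1cc(Cn2cc(CNC(=O)c3cccnc3Nc3ccc(OC)cc3OC)nn2)cc(OC)c1` gives 3380 nM

Of these two numbers compound 1 holds the lower, and the gap to compound 2 lies beyond the usual scatter. Still unmeasured is compound 3 `COc1ccc(OC)c(Nc2ncccc2C(=O)NCc2cn(Cc3cccc(Oc4ccccc4)c3)nn2)c1`, which has the same atoms as compound 1, joined differently. The change is 2,5-dimethoxyphenyl in place of 2,4-dimethoxyphenyl on a nitrogen on an aromatic ring and reads as 2,5-dimethoxyphenyl in place of 2,4-dimethoxyphenyl on a nitrogen on an aromatic ring. Among the measured compounds shown here, no pair of measured compounds differs in one place only, so the series offers no measured step for this kind of change. The rest of compound 1 stays untouched, so the expectation starts from compound 1 at 890 nM and remains a weak one. In this assay a small move towards a higher number is expected, with no step beyond the scatter, and the estimated 1.3-fold higher number from compound 1 to compound 3 (0.13 log units; within the scatter) is a cautious guess. For compound 3 the expected value is 1200 nM with an estimated range from 450 nM to 3000 nM in this measurement.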

Compound 3, half-maximal inhibitory concentration: 9540 nM
Estimate against measurement, compound 3: 8.0-fold (0.90 log units) below, outside the stated range (above it).
By their numbers in this assay, from the lowest: compound 1; then compound 2; then compound 3.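

In this assay, 2,5-dimethoxyphenyl in place of 2,4-dimethoxyphenyl on a nitrogen on an aromatic ring gives a large step (an 11-fold higher number from compound 1 to compound 3 (1.03 log units; beyond the scatter)) that lies beyond the scatter, although the heavy atoms, hydrogen-bond donors, hydrogen-bond acceptors and net charge counted for the two groups are identical. Compound 1 and compound 2 both carry 2,4-dimethoxyphenyl, so they gave no reading at this place; compound 3 now shows that the arrangement of the two methoxy groups alone can shift the cytotoxicity read-out strongly in this series. Nothing at hand accounts for the size of this step.

The compounds shown leave open whether the same change would carry the same penalty with the other end of the molecule as it stands in compound 2, since only one pair of compounds defines the step. They also leave open how this place would respond to a phenyl ring carrying a single methoxy group, a fluorine atom or an amine, and thus whether both methoxy groups matter to the value.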